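Rearranging the Alkoxy Side Chain of Compound 3

A few compounds are considered here, and "the series" means these few. Any claim that something is new, unique, unknown or untested is made for them only; others in the source may bear on it.

For the measured compounds named here, in a functional assay on MDA-MB-231 cells (Homo sapiens) for antiproliferative activity, read by sulforhodamine B assay (a higher number here means a weaker inhibitor of growth, a lower number a stronger inhibitor of growth), compound 3 `CC(C)CCCOc1cccc(O)c1C(=O)/C=C/c1ccc(O)cc1` gives 3480 nM, the only definite number among the three compounds measured. Compound 1 `O=C(/C=C/c1ccc(O)cc1)c1c(O)cccc1OCc1ccccc1` reaches only the limit of > 30000 nM in this assay. Compound 2 `CC(C)(C)CCOc1cccc(O)c1C(=O)CCc1ccc(O)cc1` likewise sits at the limit of > 30000 nM in this assay. Going by the values given here, the single measured step is an at least 8.6-fold lower number from compound 1 to compound 3 (0.93 log units; beyond the scatter), which carried the number from the limit of > 30000 nM in this assay, at which 2 of the 3 values shown sit, into the measurable range.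

Compound 4 `CCC(CC)COc1cccc(O)c1C(=O)/C=C/c1ccc(O)cc1` differs from compound 3 in one place: pentan-3-yl in place of isopentyl on a saturated chain carbon bound to an oxygen on an aromatic ring. No measured step compares two branched alkyl chains of equal size with each other, so the one step shown, between a phenyl and an isopentyl group, bears on this change only loosely, and nothing in the data separates one branching pattern from another. The expectation is therefore a step of a 1.1-fold higher number from compound 3 to compound 4 (0.06 log units; within the scatter), within the scatter. Compound 4 is expected to give 4000 nM in this assay, estimated between 1500 nM and 12000 nM.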

Compound 4, concentration for 50% growth inhibition: 3130 nM
Estimate against measurement, compound 4: 1.3-fold (0.11 log units) above; the range from low to high includes it.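

At this position, putting pentan-3-yl in place of isopentyl gives a 1.1-fold lower number from compound 3 to compound 4 (0.05 log units; within the scatter), so in this assay these two arrangements of the same five carbons cannot be told apart. A second branched alkyl group thus reaches the measurable range, and putting pentan-3-yl in place of phenyl gives an at least 9.5-fold lower number from compound 1 to compound 4 (0.98 log units; beyond the scatter). That step is a bound and not an exact size, because compound 1 stands at a limit: the limit of > 30000 nM in this assay, at which 2 of the 4 values shown sit.

The compounds shown leave open whether a shorter chain such as ethyl, a longer chain such as octyl, or a chain ending in an amine or a carboxylic acid would move the number beyond the scatter. Compound 2 differs from compound 3 in both the side chain and the carbon-carbon double bond, so neither change can be read alone.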